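Notes on the hydroxyphenyl series: compound 2 to compound 4

A few compounds are considered here, and "the series" means these few. Any claim that something is new, unique, unknown or untested is made for them only; others in the source may bear on it.

The series shares one core. Compound 1 `Oc1ccc(-c2cc(-c3ccccn3)nc(-c3ccccc3Cl)c2)cc1` has no reported result in a functional assay on DU-145 cells (Homo sapiens) for cytotoxicity, read by CCK-8 assay and cell counting, with a stated time of 2 days; a lower number here means a stronger inhibitor, a higher number a weaker inhibitor: its entry reads "not determined" (no result reported). Compound 2 `Oc1ccc(-c2cc(-c3ccco3)nc(-c3ccccc3Cl)c2)cc1` gives 5300 nM, and compound 3 `Oc1ccc(-c2cc(-c3cccc(Cl)c3)nc(-c3ccco3)c2)cc1` gives 5750 nM. Among the compounds with values here, the only measured step, a 1.1-fold higher number from compound 2 to compound 3 (0.04 log units; within the scatter), shows the two numbers indistinguishable, so compound 2 stands level with its only measured neighbour. Compound 4 `Oc1cccc(-c2cc(-c3ccco3)nc(-c3ccccc3Cl)c2)c1` differs from compound 2 by 3-hydroxyphenyl in place of 4-hydroxyphenyl on an aromatic carbon. Within the data shown here, no measured step touches the hydroxyphenyl, so nothing here bears on the change, and no shift beyond the scatter is expected in this assay. Compound 4 is therefore estimated at 5500 nM, with a range of 2000 nM to 15000 nM, meaning an expected step of a 1.0-fold higher number from compound 2 to compound 4 (0.02 log units; within the scatter).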

Compound 4, half-maximal inhibitory concentration: 1630 nM
Compound 4: middle estimate off by 3.4-fold (0.53 log units), on the high side; measured number below the stated range.
By their numbers in this assay, from the lowest: compound 4; then compounds 2 and 3 (each within the scatter of the next).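

In this assay, 3-hydroxyphenyl in place of 4-hydroxyphenyl, on the aromatic carbon opposite the ring nitrogen, gives a 3.3-fold lower number from compound 2 to compound 4 (0.51 log units; beyond the scatter). Within the data shown here, this is the only step so far beyond the scatter, and it comes with the atoms unchanged, so this position responds to where the hydroxyl stands on the phenyl group. Nothing available accounts for the shift.

Going by these compounds, whether the same change carries over to the core of compound 3 remains open. So does whether an amine or a carboxylic acid in place of the hydroxyl would hold the lower number.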